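Swapping the amine side chain on a bridged bicyclic core

The compounds below may be only part of what the source reports. "The series", "measured", "known", "first", "only" and "open" are said of these compounds alone.

Compound 1 `CN(C)C12CCN(CCN3CCCC3)C(C(c3ccccc3)C1)C(c1ccccc1)C2`: 80400 nM
Compound 2 `CN1CCN(CC(=O)N2CCC3(N4CCCC4)CC(c4ccccc4)C2C(c2ccccc2)C3)CC1`: 69100 nM
Compound 3 `CCN1CCN(CCN2CCC3(N4CCCC4)CC(c4ccccc4)C2C(c2ccccc2)C3)CC1`: 53600 nM

In an ADME assay on L6 cells (Rattus norvegicus) for cytotoxicity (a lower number here means a stronger inhibitor, a higher number a weaker inhibitor), compound 1 shows the highest of the three numbers, though its gap to compound 2 and to compound 3 stays within the scatter. The unmeasured compound 4 `CN(C)C12CCN(C(=O)CCN3CCCCC3)C(C(c3ccccc3)C1)C(c1ccccc1)C2` differs from compound 1 by (2-(piperidin-1-yl)ethyl)carbonyl in place of 2-(pyrrolidin-1-yl)ethyl on an amine nitrogen in a ring. Among the compounds with values here, the only measured step of similar kind, where a carbonyl-bearing chain gives way to a plain alkyl chain on the same ring nitrogen, is a 1.3-fold lower number from compound 2 to compound 3 (0.11 log units; within the scatter), which did not leave the scatter. No other data bear on the change. The step of a 1.0-fold lower number from compound 1 to compound 4 (0.00 log units; within the scatter) is therefore expected to stay within the scatter. Compound 4 is estimated at 80000 nM, with a range from 40000 nM to 160000 nM.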

Compound 4, half-maximal inhibitory concentration: 128000 nM
Beside the measured number, compound 4's estimate is 1.6-fold (0.20 log units) below it; measured number inside the range.
By their numbers in this assay, from the lowest: compounds 3, 2, 1 and 4 (each within the scatter of the next, the first and the last beyond it).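

On this amine nitrogen in a ring, a longer side chain that brings in a carbonyl and a six-membered ring gives a 1.6-fold higher number from compound 1 to compound 4 (0.20 log units; within the scatter) in this assay. A change between a carbonyl-bearing chain and a plain alkyl chain thus stays within the scatter on the core of compound 1 too, which carries a dimethylamino group. No measured evidence explains this result. Going by these compounds, the carbonyl and the larger ring enter together, so their separate contributions remain open. A 2-(piperidin-1-yl)ethyl group on the same nitrogen would separate them.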